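This account rests on a few compounds, and the source may have more. Where it says the series, first, only, none or still open, it means among the compounds named here.

Within the data shown here, compound 1 `COc1cc2nc(N3CCC(C(=O)NCCO)CC3)nc(N)c2cc1OC` is one of two compounds measured in an assay on isolated protein for displacement of a labelled ligand from Adrenergic receptor alpha-1 (Rattus norvegicus); a higher number here means a weaker inhibitor, a lower number a stronger inhibitor. In this assay compound 1 gives 1.73 nM, the higher of the two numbers, while compound 2 `COc1cc2nc(N3CCC(C(=O)N(C)Cc4ccccc4)CC3)nc(N)c2cc1OC` gives 0.2 nM. Among the measured compounds shown here, the only measured step, an 8.7-fold lower number from compound 1 to compound 2 (0.94 log units; beyond the scatter), puts benzyl(methyl)amino in place of (2-hydroxyethyl)amino on a carbonyl carbon and lowers the number beyond the scatter. Compound 3 `CCCCNC(=O)CC1CCN(c2nc(N)c3cc(OC)c(OC)cc3n2)CC1` has not been measured. Its difference from compound 1 is (butylcarbamoyl)methyl in place of (2-hydroxyethyl)carbamoyl on a saturated ring carbon. This change resembles the measured step in removing the (2-hydroxyethyl)carbamoyl group in favour of a group with more carbon atoms and fewer hydrogen-bond donors and acceptors, but the entering (butylcarbamoyl)methyl group is not the benzyl(methyl)amino group of compound 2, so only part of that gain is expected, as a 2.9-fold lower number from compound 1 to compound 3 (0.46 log units; beyond the scatter). Compound 3 is therefore estimated at 0.6 nM, with a likely range from 0.2 nM to 1.8 nM.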

Compound 3, inhibition constant: 1.4 nM
Compound 3: middle estimate off by 2.3-fold (0.37 log units), on the low side, within the range that was stated.
By their numbers in this assay, from the lowest: compound 2; then compounds 3 and 1 (each within the scatter of the next).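

Placing (butylcarbamoyl)methyl in place of (2-hydroxyethyl)carbamoyl on this saturated ring carbon gives a 1.2-fold lower number from compound 1 to compound 3 (0.09 log units; within the scatter), so this assay does not tell the two compounds apart. This shows that a change with more carbon atoms, and with one hydrogen-bond donor and one acceptor instead of two of each, does not by itself bring the large step seen with benzyl(methyl)amino, an 8.7-fold lower number from compound 1 to compound 2 (0.94 log units; beyond the scatter). Nothing measured here gives a reason for this result.

From the compounds shown here alone, it remains open which part of the benzyl(methyl)amino group goes with the lower number of compound 2: the benzyl group or the methyl on the amide nitrogen. Also open, going by these compounds, is how a butylcarbamoyl group without the added methylene, or a chain ending in a carboxylic acid or an amine, would read at this position.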